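Trifluoromethyl versus fluoro across two related cores

A few compounds are considered here, and "the series" means these few. Any claim that something is new, unique, unknown or untested is made for them only; others in the source may bear on it.

Compound 1 `O=C1/C(=C/c2cccc(F)c2)CN(S(=O)(=O)c2ccc(C(F)(F)F)cc2)C/C1=C\c1cccc(F)c1` gives 4200 nM in a functional assay on SMMC-7721 cells (Homo sapiens) for cytotoxicity, read by MTT assay, with a stated time of 24 h; on this read-out lower numbers stand for stronger inhibition and higher numbers for weaker inhibition. Compound 2 `O=C1/C(=C/c2cccc(F)c2)CN(S(=O)(=O)c2ccc(F)cc2)C/C1=C\c1cccc(F)c1` differs from it by fluoro in place of trifluoromethyl on an aromatic carbon and gives 13500 nM in this assay, a step of a 3.2-fold higher number from compound 1 to compound 2 (0.51 log units; beyond the scatter). Compound 3 `O=C1/C(=C/c2ccc(F)cc2)CN(S(=O)(=O)c2ccc(C(F)(F)F)cc2)C/C1=C\c1ccc(F)cc1` has the same atoms as compound 1 joined differently; the difference between the two cores is not broken down here. In this assay compound 3 gives 4400 nM, within the scatter of compound 1. Compound 4 `O=C1/C(=C/c2ccc(F)cc2)CN(S(=O)(=O)c2ccc(F)cc2)C/C1=C\c1ccc(F)cc1` is not yet measured and differs from compound 3 by fluoro in place of trifluoromethyl on an aromatic carbon, the same change as from compound 1 to compound 2, made at the same kind of place; it occurs twice among these compounds. Compound 4 is expected to show a 3.2-fold higher number from compound 3 to compound 4 (0.50 log units; beyond the scatter). Going by the values given here, that expectation rests on the single earlier step of a 3.2-fold higher number from compound 1 to compound 2 (0.51 log units; beyond the scatter) and on compound 3 sitting near compound 1. Compound 4 is therefore estimated at 14000 nM, between 7000 nM and 28000 nM.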

Compound 4, half-maximal inhibitory concentration: 14700 nM
Estimate against measurement, compound 4: 1.1-fold (0.02 log units) below; the range from low to high includes it.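

In this assay, 4-fluorophenyl in place of 4-(trifluoromethyl)phenyl gives a 3.3-fold higher number from compound 3 to compound 4 (0.52 log units; beyond the scatter), and the change carries from one core to the other with no difference beyond the scatter: the same change on two cores in this assay, a 3.2-fold higher number (0.51 log units; beyond the scatter) from compound 1 to compound 2 and a 3.3-fold higher number (0.52 log units; beyond the scatter) from compound 3 to compound 4, 1.0-fold (0.02 log units) apart, within the scatter of two such steps The two cores hold the same atoms joined differently, so this is a narrow test of transfer, resting on just two pairs of compounds. It shows nothing about cores that differ more widely, about other cell lines, or about why the step has this size.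

As far as these compounds go, how an amine or a carboxylic acid on that aromatic carbon would compare with trifluoromethyl and fluoro stays open. Also open, from the compounds shown here alone, is whether the step holds on a core carrying methoxy groups in place of its two fluoro groups.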